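The source may report more compounds than this note shows. Statements on the series, on what has been measured and on what is new or still open speak of the compounds shown alone.

Compound 1, `CCn1c(CNc2ccccc2)nnc1SCC(=O)Nc1ccc(OC)cc1`, was tested in an assay on isolated protein for inhibition of long-chain fatty acid transport protein 1 (Homo sapiens); on this read-out lower numbers stand for stronger inhibition and higher numbers for weaker inhibition. In this assay compound 1 reached only the limit of > 1000 nM, which is a bound of the measurement rather than a number. Compound 2, `CCn1c(CNc2ccccc2)nnc1SCc1nc2cc(Cl)ccc2o1`, likewise gave only a limit of > 1000 nM in this assay. Compound 3, `CCC(=O)c1ccc2oc(CS(=O)(=O)c3nnc(CNc4ccccc4)n3CC)nc2c1`, gives 1670 nM in this assay. So compound 1 stands at the limit of > 1000 nM in this assay, at which 2 of the 3 values shown sit, without a measured number of its own. For the measured compounds named here, no step between measured compounds that differ in one place is available, so no measured step size is known here.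

Compound 4, `CCn1c(CNc2ccccc2)nnc1SCC(=O)Nc1ccc(C(=O)OC(C)(C)C)cc1`, differs from compound 1 by tert-butoxycarbonyl in place of methoxy on an aromatic carbon. Compound 1 gives only the limit of > 1000 nM in this assay. On that basis compound 4 is expected to remain weak, with an expected step that the limit leaves unreadable from compound 1 to compound 4, which is no change beyond the scatter. Compound 4 is therefore estimated at 2000 nM in this assay, most likely between 700 nM and 6000 nM.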

Compound 4, half-maximal inhibitory concentration: > 1000 nM
Compound 4: only a limit was reported; the forecaster's own chance of this, stated with the estimate: 60%; the middle value does not contradict the limit.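

Compound 1 and compound 4 each gave only a limit in this assay, so no step can be read between them for tert-butoxycarbonyl in place of methoxy on an aromatic carbon. The compounds shown leave open how strongly those sitting at a limit inhibit: the limit of > 1000 nM in this assay, at which 3 of the 4 values shown sit.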